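The compounds below may be only part of what the source reports. "The series", "measured", "known", "first", "only" and "open" are said of these compounds alone.

Measured in a functional assay on HL60/MX2 cells (Homo sapiens) for antiproliferative activity, read by MTT assay, with a stated time of 48 h; on this read-out lower numbers stand for stronger inhibition and higher numbers for weaker inhibition:
- Compound 1 `Cn1c(N)c(-c2nc3ccccc3[nH]2)c2nc(C#N)c(C#N)nc21`: > 50000 nM, a limit
- Compound 2 `CCCCn1c(N)c(-c2nc3ccccc3[nH]2)c2nc(C#N)c(C#N)nc21`: > 50000 nM, a limit

Compound 1 has no number in this assay, only the limit given above, and both measured compounds sit at the limit of > 50000 nM in this assay, at which 2 of the 2 values shown sit. Compound 3 `CN(C)CCCCn1c(-c2c(N)n(C)c3nc(C#N)c(C#N)nc23)nc2ccccc21` is built from compound 1 by one change: 4-(dimethylamino)butyl in place of hydrogen on an aromatic nitrogen.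

For the measured compounds named here, the only measured step is a step that the two limits leave unreadable from compound 1 to compound 2. It lies at another place, on a saturated chain carbon bound to an aromatic nitrogen, and it gives no usable size. The expectation is therefore loose: some stronger inhibition, with a fair chance that compound 3 also ends at a limit. The estimated change is an at least 3.3-fold lower number from compound 1 to compound 3 (0.52 log units; beyond the scatter). Compound 3 is expected at 15000 nM, within an estimated range of 2000 nM to 60000 nM.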

Compound 3, half-maximal inhibitory concentration: 2810 nM
Estimate against measurement, compound 3: 5.3-fold (0.73 log units) above; the measured number falls inside the stated range.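

In this assay the exchange of hydrogen for 4-(dimethylamino)butyl on the aromatic nitrogen of the five-membered ring gives an at least 17-fold lower number from compound 1 to compound 3 (1.25 log units; beyond the scatter) and so shows that substitution at this nitrogen can bring a large gain in inhibition. For the compounds shown here, the earlier compounds showed nothing about this position: their only step lies at another place, on a saturated chain carbon bound to an aromatic nitrogen, and it cannot be read. Compound 3 is the only compound shown with a number, while the other two stand at a limit: the limit of > 50000 nM in this assay, at which 2 of the 3 values shown sit.

The compounds shown leave open whether the dimethylamino group is needed or a plain butyl on the same nitrogen would do as well. A propyl chain carrying the same amine, or a butyl chain ending in a morpholine, would test how far the gain depends on chain and amine.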